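The source may report more compounds than this note shows. Statements on the series, on what has been measured and on what is new or still open speak of the compounds shown alone.

- Compound 1 `O=C1CS/C(=N/Nc2nncc3ccccc23)N1c1ccccc1`: 77 nM
- Compound 2 `Cc1cc(C)nc(NS(=O)(=O)c2ccc(Nc3nncc4ccccc34)cc2)n1`: 7.7 nM

In a functional assay on MCF7 cells (Homo sapiens) for antiproliferative activity, read by sulforhodamine B assay, with a stated time of 72 h (on this read-out higher numbers stand for weaker inhibition and lower numbers for stronger inhibition), compound 2 holds the lower of the two numbers at 7.7 nM, and the gap to compound 1 at 77 nM lies beyond the scatter. Compound 3 `O=S(=O)(Nc1ncccn1)c1ccc(Nc2nncc3ccccc23)cc1` has not yet been measured. It carries pyrimidin-2-yl in place of 4,6-dimethylpyrimidin-2-yl on a sulfonamide nitrogen. Within the data shown here, no measured pair shows what this change does. In this assay, the expected step is small and toward a higher number, probably not beyond the scatter: a 1.6-fold higher number from compound 2 to compound 3 (0.19 log units; within the scatter). Compound 3 is expected at 12 nM, within an estimated range of 4 nM to 40 nM.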

Compound 3, half-maximal inhibitory concentration: 64 nM
Estimate against measurement, compound 3: 5.3-fold (0.73 log units) below; measured number outside the range, above it.
By their numbers in this assay, from the lowest: compound 2; then compounds 3 and 1 (each within the scatter of the next).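

In this assay, pyrimidin-2-yl in place of 4,6-dimethylpyrimidin-2-yl on a sulfonamide nitrogen gives an 8.3-fold higher number from compound 2 to compound 3 (0.92 log units; beyond the scatter). The position is therefore sensitive to this change, which leaves the ring type and the counted donors and acceptors the same and removes two heavy atoms. Nothing shown here accounts for the size of this step.

The compounds shown leave open whether both methyl groups are needed, or whether a single methyl group would do. They also leave open how an ethyl group, a methoxy group or an acetyl group would fare.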